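Cyclopentylmethyl on the aryl nitrogen: a cytotoxicity forecast

The compounds below may be only part of what the source reports. "The series", "measured", "known", "first", "only" and "open" are said of these compounds alone.

Measured so far:
compound 1 `CCCCN(c1ccnc(Nc2ccc(C#N)cc2)n1)c1c(F)cc(-c2ccc(C#N)cc2)cc1F`: 211000 nM
compound 2 `N#Cc1ccc(Nc2nccc(N(c3c(F)cc(-c4ccc(C#N)cc4)cc3F)C3CCCC3)n2)cc1`: 232000 nM

In an ADME assay on MT4 cells (Homo sapiens) for cytotoxicity, read by MTT assay, with a stated time of 5 days (on this read-out lower numbers stand for higher toxicity in this test and higher numbers for lower toxicity in this test), compound 2 stands highest of the two numbers, and its nearest neighbour is compound 1: the step of a 1.1-fold higher number from compound 1 to compound 2 (0.04 log units; within the scatter) lies within the scatter, so the two compounds cannot be told apart on this read-out.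

Compound 3 `N#Cc1ccc(Nc2nccc(N(CC3CCCC3)c3c(F)cc(-c4ccc(C#N)cc4)cc3F)n2)cc1` is the next compound, not yet measured. It differs from compound 2 as follows: cyclopentylmethyl in place of cyclopentyl on a nitrogen on an aromatic ring.

Among the compounds with values here, only one measured step bears on this change, the exchange of the same nitrogen substituent described by a 1.1-fold higher number from compound 1 to compound 2 (0.04 log units; within the scatter), and that step did not leave the scatter. On that basis the step from compound 2 to compound 3 is expected to be small, with no clear direction: the estimated change is a 1.1-fold lower number from compound 2 to compound 3 (0.02 log units; within the scatter). For compound 3 the expected value is 220000 nM, with a range from 110000 nM to 440000 nM.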

Compound 3, half-maximal cytotoxic concentration: > 247000 nM
Compound 3: a limit, no number; the forecaster's own chance of this, stated with the estimate: 20%; middle value at least 1.1-fold (0.05 log units) away from the limit.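

In this assay compound 3 gives > 247000 nM as a limit and not a number. On these data alone, the steps can be read only as floors: an at least 1.0-fold higher number from compound 2 to compound 3 (0.02 log units; that floor lies within the scatter) and an at least 1.1-fold higher number from compound 1 to compound 3 (0.06 log units; that floor lies within the scatter) both stop within the scatter, so the true size of each stays unknown. What is new is that cyclopentylmethyl, with 6 heavy atoms, in place of cyclopentyl, with 5, on a nitrogen on an aromatic ring brings no lower number in this test, and the reading reaches the limit of the assay.

As far as these compounds go, how far compound 3 really stands from compound 1 and compound 2 remains open, as a limit gives no number to compare. Also open, from the compounds shown here alone, is how this test would read with an amine or a carboxylic acid on a chain at this nitrogen in place of these all-carbon groups.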